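Notes on an azole exchange in the sulfonylcarbamate series

The compounds below may be only part of what the source reports. "The series", "measured", "known", "first", "only" and "open" are said of these compounds alone.

Measured so far:
compound 1 `CCCCOC(=O)NS(=O)(=O)c1sc(CC(C)C)cc1-c1ccc(CN2CCN(C)C2=O)cc1` — 16.5 nM
compound 2 `CCCCOC(=O)NS(=O)(=O)c1sc(CC(C)C)cc1-c1ccc(Cn2cnc(C(F)(F)F)c2)cc1` — 7.3 nM

In an assay on membranes from uterus for displacement of a labelled ligand from Angiotensin type II receptor (Sus scrofa), with a stated time of 1.5 h (on this read-out lower numbers stand for stronger inhibition and higher numbers for weaker inhibition), compound 2 stands lowest of the two numbers shown, set apart from the other value by the single step of a 2.3-fold lower number from compound 1 to compound 2 (0.35 log units; beyond the scatter), a modest one beyond the scatter. Compound 3 `CCCCOC(=O)NS(=O)(=O)c1sc(CC(C)C)cc1-c1ccc(Cn2cccn2)cc1` differs from compound 2 by 1H-pyrazol-1-yl in place of 4-(trifluoromethyl)-1H-imidazol-1-yl on a saturated chain carbon bound to an aromatic carbon. For the measured compounds named here, that one earlier step is the only measured change at this position and bears only loosely on the new one. A modest rise is expected, a 2.1-fold higher number from compound 2 to compound 3 (0.31 log units; beyond the scatter). For compound 3 the estimated value in this assay is 15 nM, with a range from 5 nM to 45 nM.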

Compound 3, inhibition constant: 2.3 nM
Compound 3: middle estimate off by 6.5-fold (0.81 log units), on the high side; measured number below the stated range.
By their numbers in this assay, from the lowest: compound 3; then compound 2; then compound 1.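

In this assay, on a saturated chain carbon bound to an aromatic carbon, 1H-pyrazol-1-yl in place of 4-(trifluoromethyl)-1H-imidazol-1-yl gives a 3.2-fold lower number from compound 2 to compound 3 (0.50 log units; beyond the scatter) and shows that trifluoromethyl is not required for a low number here. In place of 3-methyl-2-oxoimidazolidin-1-yl, the same group gives a 7.2-fold lower number from compound 1 to compound 3 (0.86 log units; beyond the scatter) in this series. Nothing available explains either step.

Going by these compounds, the step from compound 2 to compound 3 changes both the ring and the trifluoromethyl group, so their separate contributions remain open. Unsubstituted 1H-imidazol-1-yl would separate them.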